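Swapping Ethyl for 4-Fluorophenyl on the Carbonyl Carbon

The source may report more compounds than this note shows. Statements on the series, on what has been measured and on what is new or still open speak of the compounds shown alone.

Of the compounds shown here, three built on one shared core have been tested in an assay on isolated protein for inhibition of aldehyde dehydrogenase 1A1 (Homo sapiens), read by spectrophotometry, tested at 10 uM; on this read-out lower numbers stand for less inhibition and higher numbers for more inhibition at the one concentration tested (going by the name of the read-out). Compound 3 `CCC(=O)N1CCN(Cc2nc3ccccc3n2Cc2cccc(C)c2)CC1` stands highest of the three, giving 85.1% in this assay. Compound 1 `CCc1ccc(C(=O)N2CCN(Cc3nc4ccccc4n3Cc3cccc(C)c3)CC2)cc1` gives 67%, and compound 2 `Cc1cccc(Cn2c(CN3CCN(C(=O)c4ccc(C(C)C)cc4)CC3)nc3ccccc32)c1` gives 67.6%. Each of these two carries a substituted phenyl ring on the carbonyl carbon where compound 3 carries ethyl. The step of a number 18.1 percentage points higher from compound 1 to compound 3 (beyond the scatter) and the step of a number 17.5 percentage points higher from compound 2 to compound 3 (beyond the scatter) show that ethyl on that carbonyl carbon goes with more inhibition at this concentration, while the step of a number 0.6 percentage points higher from compound 1 to compound 2 (within the scatter) lies within the scatter, so the two phenyl-bearing compounds cannot be told apart.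

Compound 4 `Cc1cccc(Cn2c(CN3CCN(C(=O)c4ccc(F)cc4)CC3)nc3ccccc32)c1` has not yet been measured. It differs from compound 3 in one place: 4-fluorophenyl in place of ethyl on a carbonyl carbon. This runs in the reverse direction of the two steps that mattered, ethyl giving way to a substituted phenyl ring on the same carbonyl carbon. Those two steps were modest and alike in size, so a comparable fall is expected here, although fluorine is neither ethyl nor isopropyl and the measured compounds offer no direct guide to it. The expected step is a number 16.1 percentage points lower from compound 3 to compound 4 (beyond the scatter). Compound 4 is therefore estimated at 69%, within a range from 55% to 82%.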

Compound 4, a percentage reported as inhibition, at one concentration (the size of the read-out at that concentration, not a potency): 27.1%
Compound 4: middle estimate off by 41.9 percentage points, on the high side; measured number outside the range, below it.
By their numbers in this assay, from the lowest: compound 4; then compounds 1 and 2 (each within the scatter of the next); then compound 3.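

Putting 4-fluorophenyl in place of ethyl on the carbonyl carbon gives a number 58 percentage points lower from compound 3 to compound 4 (beyond the scatter), a much larger fall than either earlier step from a substituted phenyl ring to ethyl, so carrying a phenyl ring there does not by itself fix the level of inhibition in this assay. The group on the ring's aromatic carbon matters as well: fluoro in place of isopropyl gives a number 40.5 percentage points lower from compound 2 to compound 4 (beyond the scatter), and fluoro in place of ethyl gives a number 39.9 percentage points lower from compound 1 to compound 4 (beyond the scatter), whereas ethyl and isopropyl on that carbon could not be told apart. Nothing available explains why fluoro goes with so much less inhibition at this concentration than ethyl or isopropyl on that ring.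

The compounds shown leave open where a plain phenyl ring, or chloro or methoxy on that aromatic carbon, would fall, so it remains unclear whether fluoro stands alone or marks a wider trend among groups at this place. From the compounds shown here alone, it is also open whether the high number seen with ethyl on the carbonyl carbon would hold for a longer chain such as butyl or a saturated ring such as cyclohexyl.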